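The source may report more compounds than this note shows. Statements on the series, on what has been measured and on what is new or still open speak of the compounds shown alone.

Measured compounds:
Compound 1 `Nc1nc(N)c(CCCN(Cc2ccc(NC(CCC(=O)O)C(=O)O)cc2)c2cc(F)c([N+](=O)[O-])cc2[N+](=O)[O-])c(O)n1` gives 40000 nM in a functional assay on CCRF-CEM cells (Homo sapiens) for cytotoxicity, in the absence of a further agent; on this read-out lower numbers stand for stronger inhibition and higher numbers for weaker inhibition.
Compound 2 `Nc1nc(N)c(CCCN(Cc2ccc(NC(CCC(=O)O)C(=O)O)cc2)c2cc(F)c(F)cc2[N+](=O)[O-])c(O)n1` reaches only the limit > 100000 nM in this assay, so no number is known for it.
Compound 3 `Nc1nc(N)c(CCCNc2cc(F)c([N+](=O)[O-])cc2[N+](=O)[O-])c(O)n1` gives 1000 nM in this assay.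

Compound 4 `Nc1nc(N)c(CCCNc2cc(F)c(F)cc2[N+](=O)[O-])c(O)n1` has not yet been measured. It arises from compound 3 by one change, (fluoro in place of nitro on an aromatic carbon). The same change turns compound 1 into compound 2, (fluoro in place of nitro on an aromatic carbon), and there it produced an at least 2.5-fold higher number from compound 1 to compound 2 (0.39 log units; beyond the scatter), a step whose true size is open because compound 2 sits at the limit of > 100000 nM in this assay, at which 1 of the 3 values shown sits. The difference between the core of compound 3 and the core of compound 1 is not broken down here. For compound 4 a weakening of similar kind is expected, estimated as a 5.0-fold higher number from compound 3 to compound 4 (0.70 log units; beyond the scatter), resting on the measured step from compound 1 to compound 2. Compound 4 is therefore expected to give about 5000 nM in this assay, between 2000 nM and 30000 nM.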

Compound 4, half-maximal inhibitory concentration: 97000 nM
For compound 4 the middle estimate is 19-fold (1.29 log units) below the measured one; measured number above the stated range.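

In this assay, putting fluoro in place of the nitro group on the core of compound 3 gives a 97-fold higher number from compound 3 to compound 4 (1.99 log units; beyond the scatter). The same change also gave a weaker result on the other core, so its direction carried over between these two cores: the same change on two cores in this assay, an at least 2.5-fold higher number (0.39 log units; beyond the scatter) from compound 1 to compound 2 and a 97-fold higher number (1.99 log units; beyond the scatter) from compound 3 to compound 4; the limit leaves it open whether they differ. For compound 2, > 100000 nM is a limit of the assay and not a number, so the pair of steps shows a shared direction but no shared size.

As far as these compounds go, only these two cores carry the change, so other cores remain untested here. Also open, from the compounds shown here alone, is how a nitrile or a methoxy group in place of the nitro group would read in this assay.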